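Urea Aryl Swap in a Cell Growth Series

This account rests on a few compounds, and the source may have more. Where it says the series, first, only, none or still open, it means among the compounds named here.

Compound 1 `O=C(Nc1cccc(-n2cc(-c3ccncc3)c(-c3ccc(Cl)c(O)c3)n2)c1)Nc1cccc(C(F)(F)F)c1` gives 12600 nM in a functional assay on MDA-MB-435 cells (Homo sapiens) for inhibition, read by sulforhodamine B assay, with a stated time of 48 h; a lower number here means a stronger inhibitor of growth, a higher number a weaker inhibitor of growth.
Compound 2 `COc1cc(-c2nn(-c3cccc(NC(=O)Nc4cc(C(F)(F)F)cc(C(F)(F)F)c4)c3)cc2-c2ccncc2)ccc1Cl` gives 1990 nM in this assay.
Compound 3 `COc1cc(-c2nn(-c3cccc(NC(=O)c4cccc(C(F)(F)F)c4)c3)cc2-c2ccncc2)ccc1Cl` gives 1770 nM in this assay.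

Of the three measured compounds, compound 1 stands highest; its value lies beyond the scatter from both compound 2 and compound 3, which differ from it in more than one place, so no single step can be read from them. Between compound 2 and compound 3 themselves the two values lie within the scatter of each other.

Compound 4 `O=C(Nc1cccc(-n2cc(-c3ccncc3)c(-c3ccc(Cl)c(O)c3)n2)c1)Nc1ccc(Cl)c(Cl)c1` is the unmeasured analogue of compound 1. The change is 3,4-dichlorophenyl in place of 3-(trifluoromethyl)phenyl on an amide-type nitrogen. Both groups carry no hydrogen-bond donors or acceptors and no net charge, and the place on the urea nitrogen is unchanged, so the step is a swap of one substituted phenyl for another at the far end of the urea.

Within the data shown here, with no measured pair showing this particular swap, the expected step from compound 1 to compound 4 in this assay is taken to be small and possibly downward, a 1.6-fold lower number from compound 1 to compound 4 (0.20 log units; within the scatter), not clearly beyond the scatter. Compound 4 is therefore estimated at 8000 nM, with a range from 3000 nM to 25000 nM.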

Compound 4, concentration for total growth inhibition: 6050 nM
Estimate against measurement, compound 4: 1.3-fold (0.12 log units) above; low and high end bracket the measured number.
By their numbers in this assay, from the lowest: compounds 3 and 2 (each within the scatter of the next); then compound 4; then compound 1.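

Among these compounds, this is the first step that can be read at a single place: in this assay, with 3,4-dichlorophenyl in place of 3-(trifluoromethyl)phenyl on an amide-type nitrogen, the result is a 2.1-fold lower number from compound 1 to compound 4 (0.32 log units; beyond the scatter). The aryl group at the far end of the urea can therefore shift the growth-inhibition number by a modest but readable amount while the rest of compound 1 stays unchanged, even though the two groups match in their aromatic ring, their donor and acceptor counts and their lack of net charge. No measurement of any property of these two groups accompanies the step, so what lies behind it remains unexplained.

The compounds shown give only this one swap on the urea nitrogen, so it remains open whether an unsubstituted phenyl, a single chlorine, or a phenyl ring carrying an amine or a carboxylic acid would move the number further, and in which direction. On these data alone, it also remains open whether the same swap would give a similar step on a different aryl group elsewhere in the core of compound 1.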